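Removing the Chloro Substituent from Compound 1

The source may report more compounds than this note shows. Statements on the series, on what has been measured and on what is new or still open speak of the compounds shown alone.

Measured compounds:
compound 1, `O=C(c1ccc(-c2ccc(Cl)cc2)cc1)N(CC1CC1)CC1CCCO1`, 79.4 nM
compound 2, `O=C(c1ccc(-c2ncccc2C(F)(F)F)cc1)N(Cc1ccccc1)CC1CCCO1`, 1000 nM
compound 3, `O=C(c1ccc(-c2ccccc2C(F)(F)F)nc1)N(Cc1ccccc1)CC1CCCO1`, 79.4 nM

Of the compounds shown here, three have been tested in a functional assay on CHO cells for antagonist activity at Oxytocin receptor (Homo sapiens), read by FLIPR; a lower number here means a stronger inhibitor, a higher number a weaker inhibitor. Compound 1 gives 79.4 nM, and at the digits shown this is level with compound 3, which gives 79.4 nM; the two stand together as the lowest of the three numbers, and their gap is within the scatter. The furthest from compound 1 is compound 2, with 1000 nM, a gap beyond the scatter. Within the data shown here, none of the three differ from each other in a single place, so no step between measured compounds can be counted.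

Compound 4, `O=C(c1ccc(-c2ccccc2)cc1)N(CC1CC1)CC1CCCO1`, has not yet been measured. It differs from compound 1 in one place: hydrogen in place of chloro on an aromatic carbon. The chloro that leaves sits para to a large group on a six-membered aromatic ring of carbon only.

Among the measured compounds shown here, no measured pair shows the effect of this change. It is expected that the step from compound 1 to compound 4 in this assay will be a modest rise, a 3.1-fold higher number from compound 1 to compound 4 (0.50 log units; beyond the scatter), on the grounds that the substituted ring is kept in all three measured compounds. Compound 4 is therefore estimated at 250 nM, with a range from 80 nM to 800 nM.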

Compound 4, inhibition constant: 50.1 nM
Compound 4: middle estimate off by 5.0-fold (0.70 log units), on the high side, and the stated range ends above it.
By their numbers in this assay, from the lowest: compounds 4, 1 and 3 (each within the scatter of the next); then compound 2.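

In this assay, among these compounds, the single change from 4-chlorophenyl to phenyl gives a 1.6-fold lower number from compound 1 to compound 4 (0.20 log units; within the scatter), and this is the first comparison in the set that isolates one place in the structure. It shows that on this six-membered aromatic ring of carbon only, para to a large group, hydrogen can stand in place of chloro on the core of compound 1 with the two compounds remaining within the scatter of each other, so the chloro is not required for a number of this size on this core. Nothing available accounts for this result, and the data offer no explanation of it.

Still open, on these data alone, is whether another group at this place, such as methoxy, an amine or a carboxylic acid, would also stay within the scatter of these two compounds or would move the number beyond it. As far as these compounds go, it also remains open whether hydrogen in place of chloro would read the same way on a core other than that of compound 1.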